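The source may hold more compounds than are shown below. What is called first, only, known or untested is meant among the compounds shown, and "the series" means these compounds.

Series notes. Compound 1 `C/C1=C\CC[C@@]2(C)O[C@@H]2C(=O)[C@@H]2CC[C@@H](C)[C@](C)(CC1)[C@H]2COC(=O)Oc1ccccc1` gives 550 nM in an assay (Oryctolagus cuniculus) for inhibition of platelet-activating factor receptor (Cavia porcellus); a lower number here means a stronger inhibitor, a higher number a weaker inhibitor. Compound 2 `C/C1=C\CC[C@@]2(C)O[C@@H]2C(=O)[C@@H]2CC[C@@H](C)[C@](C)(CC1)[C@H]2COc1ccon1` gives 50 nM in this assay; the single-point change from compound 1 to compound 2 is an 11-fold lower number from compound 1 to compound 2 (1.04 log units; beyond the scatter), 1,2-oxazol-3-yl in place of phenoxycarbonyl on an oxygen on a saturated carbon. Compound 3 `CC(=O)OC[C@H]1[C@H]2CC[C@@H](C)[C@]1(C)CC/C(C)=C/CC[C@@]1(C)O[C@@H]1[C@@H]2O` has a core that is not the shared core of the first two compounds. In this assay compound 3 gives 80 nM. Among the three numbers compound 3 stands second highest; its gap to compound 2 is within the scatter, its gap to compound 1 is beyond it.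

Compound 4 `COC(=O)OC[C@H]1[C@H]2CC[C@@H](C)[C@]1(C)CC/C(C)=C/CC[C@@]1(C)O[C@@H]1[C@@H]2O` differs from compound 3 by methoxy in place of methyl on a carbonyl carbon; cut one bond further out, acetoxymethyl becomes ((methoxycarbonyl)oxy)methyl. Among the measured compounds shown here, no measured step touches this carbonyl carbon. For the measured compounds named here, the only measured step, from compound 1 to compound 2, replaces the whole group on the oxygen and sits on a different core, so it bears on this change only loosely. The expected step is a 1.5-fold higher number from compound 3 to compound 4 (0.18 log units; within the scatter), a somewhat higher number but close to the scatter. Compound 4 is estimated at 120 nM in this assay, with a range from 40 nM to 400 nM.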

Compound 4, half-maximal inhibitory concentration: 130 nM
Estimate against measurement, compound 4: 1.1-fold (0.03 log units) below, and the stated range covers the measured number.
By their numbers in this assay, from the lowest: compounds 2, 3 and 4 (each within the scatter of the next, the first and the last beyond it); then compound 1.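

Among the compounds shown here, this is the first reading at this carbonyl carbon: with methoxy in place of methyl, this assay shows a 1.6-fold higher number from compound 3 to compound 4 (0.21 log units; within the scatter), so acetoxymethyl and ((methoxycarbonyl)oxy)methyl cannot be told apart on the core of compound 3. The added oxygen, with its one extra hydrogen-bond acceptor, therefore brings no change beyond the scatter here, unlike the large replacement of the whole group on the oxygen in the core of compound 1. No supporting measurement bears on why the two groups read alike.

Still open, on these data alone, is whether a carbonyl carbon bearing an amine or a longer chain such as butoxy would stay within the scatter of compound 3. Also open is whether an 11-fold lower number from compound 1 to compound 2 (1.04 log units; beyond the scatter) carries over to the core of compound 3, where 1,2-oxazol-3-yl and phenoxycarbonyl are not shown.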